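This account rests on a few compounds, and the source may have more. Where it says the series, first, only, none or still open, it means among the compounds named here.

Measured in a functional assay on MCF cells (Homo sapiens) for antiproliferative activity, with a stated time of 72 h; a higher number here means a weaker inhibitor, a lower number a stronger inhibitor:
- Compound 1 `OC[C@H]1O[C@@H](n2cnc3c(NCc4ccc(F)cc4)ncnc32)[C@H](O)[C@@H]1O`: 21000 nM
- Compound 2 `COc1cccc(CNc2ncnc3c2ncn3[C@@H]2O[C@H](CO)[C@@H](O)[C@H]2O)c1OC`: > 166000 nM, a limit

Compound 2 stands at the limit of > 166000 nM in this assay, at which 1 of the 2 values shown sits, so it has no exact number and is the weaker of the two. Compound 3 `COc1ccc(CNc2ncnc3c2ncn3[C@@H]2O[C@H](CO)[C@@H](O)[C@H]2O)c(OC)c1` has the same atoms as compound 2, joined differently: 2,4-dimethoxyphenyl in place of 2,3-dimethoxyphenyl on a saturated chain carbon bound to a nitrogen on an aromatic ring. Within the data shown here, the only measured step is an at least 7.9-fold higher number from compound 1 to compound 2 (0.89 log units; beyond the scatter), which lies beyond the scatter. It replaces 4-fluorophenyl with 2,3-dimethoxyphenyl, so it is only a loose guide. Among the measured compounds shown here, no measured step swaps one dimethoxyphenyl for another. Compound 3 is therefore expected to stay weak in this assay, with no clear move from compound 2 beyond the scatter, and it may also return only a limit. The expected change is an at least 1.1-fold lower number from compound 2 to compound 3 (0.07 log units; that floor lies within the scatter). For compound 3 the estimated value is 140000 nM, with an expected range of 40000 nM to 300000 nM.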

Compound 3, half-maximal inhibitory concentration: > 166000 nM
Compound 3 gave a limit, no number; the forecaster's own chance of this, stated with the estimate: 55%; middle value at least 1.1-fold (0.07 log units) away from the limit.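

Swapping 2,3-dimethoxyphenyl for 2,4-dimethoxyphenyl on a saturated chain carbon bound to a nitrogen on an aromatic ring cannot be read in this assay, since compound 2 and compound 3 both end at a limit rather than a number: the limit of > 166000 nM in this assay, at which 2 of the 3 values shown sit.

What the result does add is a second example of leaving 4-fluorophenyl: it gives an at least 7.9-fold higher number from compound 1 to compound 3 (0.89 log units; beyond the scatter), which has the same floor as an at least 7.9-fold higher number from compound 1 to compound 2 (0.89 log units; beyond the scatter). Among these three compounds, then, both dimethoxyphenyl groups give a clearly weaker result than the 4-fluorophenyl group.

From the compounds shown here alone, how far apart compound 2 and compound 3 truly lie remains unknown. Going by these compounds, it is also open whether a phenyl group carrying a single methoxy group, or an amino group in place of the methoxy groups, would return a true number.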